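Chloro and hydroxy changes on a pyrazole urea scaffold

A few compounds are considered here, and "the series" means these few. Any claim that something is new, unique, unknown or untested is made for them only; others in the source may bear on it.

Compound 1 `O=C(Nc1cccc(-n2cc(-c3ccncc3)c(-c3ccc(Cl)c(O)c3)n2)c1)Nc1cccc(C(F)(F)F)c1`: in a functional assay on MCF7 cells (Homo sapiens) for inhibition, read by sulforhodamine B assay, with a stated time of 48 h (on this read-out lower numbers stand for higher toxicity in this test and higher numbers for lower toxicity in this test), compound 1 gives > 32500 nM, a limit of the assay rather than a number.
Compound 2 `COc1cc(-c2nn(-c3cccc(NC(=O)Nc4cccc(C(F)(F)F)c4)c3)cc2-c2ccncc2)ccc1Cl`: in this assay compound 2 gives > 50000 nM, also a limit.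
Compound 3 `COc1cc(-c2nn(-c3cccc(NC(=O)Nc4ccc(Cl)c(C(F)(F)F)c4)c3)cc2-c2ccncc2)ccc1Cl`: in this assay compound 3 gives > 32500 nM, again a limit.

For the measured compounds named here, all three measured values are limits, so no step among them can be read. The change from compound 2 to compound 1, (hydrogen in place of methyl on an oxygen on an aromatic ring), yields a step that the two limits leave unreadable from compound 2 to compound 1. The two cores differ as described by chloro in place of hydrogen on an aromatic carbon, and that step reads a step that the two limits leave unreadable from compound 2 to compound 3. Two of the three values sit at the limit of > 32500 nM in this assay, at which 2 of the 3 values shown sit, and one at the limit of > 50000 nM in this assay, at which 1 of the 3 values shown sits.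

Compound 4 `O=C(Nc1cccc(-n2cc(-c3ccncc3)c(-c3ccc(Cl)c(O)c3)n2)c1)Nc1ccc(Cl)c(C(F)(F)F)c1` has not yet been measured. It differs from compound 3 by hydrogen in place of methyl on an oxygen on an aromatic ring, the same change already made from compound 2 to compound 1. Since the earlier step could not be sized and every value shown is a limit, the expectation rests only on the observation that compound 1, compound 2 and compound 3 all reach a limit in this assay; compound 4 is therefore expected to give 40000 nM, which means an estimated step that the limit leaves unreadable from compound 3 to compound 4.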

Compound 4, concentration lethal to 50% of the cells: > 32500 nM
Compound 4: a limit, no number; the forecaster's own chance of this, stated with the estimate: 85%; the middle value is on the limit's open side.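

In this assay compound 4 gives > 32500 nM, again a limit and not a number. The steps from compound 3 to compound 4 and from compound 1 to compound 4 cannot be read. The compounds shown leave open whether methoxy to hydroxy, or chloro in place of hydrogen, changes the read-out in this assay at all.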